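This account rests on a few compounds, and the source may have more. Where it says the series, first, only, none or still open, it means among the compounds named here.

Notes on the series. Compound 1 `NC(=O)/C=C/c1ccncc1-c1ccc2ccccc2c1` carries a carbamoyl group at the end of the chain. In a functional assay on A549 cells (Homo sapiens) for inhibition, read by sulforhodamine B assay, with a stated time of 72 h (a higher number here means a weaker inhibitor of growth, a lower number a stronger inhibitor of growth), compound 1 gives only a limit, > 10000 nM, and no number. Compound 3 `CNC(=O)/C=C/c1ccncc1-c1ccc2c(cnn2C)c1` also returns only a limit in this assay, > 10000 nM. Among the compounds with values here, compound 2 `CCOC(=O)/C=C/c1ccncc1-c1ccc2c(ccn2C)c1` is the single member with a measured number in this assay, 1720 nM. Within the data shown here, compound 1 therefore sits at the limit of > 10000 nM in this assay, at which 2 of the 3 values shown sit, and no step between measured compounds is available to guide the next change. Compound 4 `CN(C)C(=O)/C=C/c1ccncc1-c1ccc2ccccc2c1` remains to be measured; it differs from compound 1 by dimethylamino in place of amino on a carbonyl carbon. The step from compound 1 to compound 4 is expected to be small, if anything toward stronger inhibition, and quite possibly within the scatter. Compound 4 is estimated at 8000 nM, with a range of 2000 nM to 30000 nM, which means an expected step of an at least 1.2-fold lower number from compound 1 to compound 4 (0.09 log units; that floor lies within the scatter).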

Compound 4, concentration for 50% growth inhibition: 5800 nM
Compound 4: the middle estimate sits 1.4-fold (0.14 log units) above what was measured; the measured number falls inside the stated range.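

On the core of compound 1, dimethylamino on the carbonyl carbon gives a measured number in this assay, where compound 4 reads 5800 nM. On these data alone, the change reads as an at least 1.7-fold lower number from compound 1 to compound 4 (0.23 log units; that floor lies within the scatter), and only this floor is known, so the full size of the step stays open. Compound 1 stands at a limit, not a number: the limit of > 10000 nM in this assay, at which 2 of the 4 values shown sit.

The compounds shown leave open how diethylamino or pyrrolidinyl on the same carbonyl carbon, or a carboxylic acid in place of the amide, would read. Whether dimethylamino also gives a number on the core of compound 3 is open too.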